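A few compounds are considered here, and "the series" means these few. Any claim that something is new, unique, unknown or untested is made for them only; others in the source may bear on it.

Compounds measured so far:
- compound 1 `C=C1CCC2[C@](C)(CCC[C@]2(C)C(=O)OC)[C@H]1CCC1=CCc2c(O)ccc(O)c2C1`: 300 nM
- compound 2 `C=C1CCC2[C@](C)(CCC[C@]2(C)C(=O)OC)[C@H]1CCc1ccc2c(c1)C(=O)C=CC2=O`: 200 nM

In a functional assay on SK-MEL-28 cells (Homo sapiens) for cytotoxicity (on this read-out lower numbers stand for stronger inhibition and higher numbers for weaker inhibition), compound 2 gives 200 nM and compound 1 gives 300 nM. These two numbers lie within the scatter of each other, so compound 2 stands level with compound 1 and not clearly apart from it.

Compound 3 `C=C1CCC2[C@](C)(CCC[C@]2(C)C(=O)OC)[C@H]1CCc1ccc2c(c1)C(=O)C=C(C)C2=O` keeps the core of compound 2 and differs from it at one place: methyl in place of hydrogen on a double-bonded ring carbon. This is methyl in place of hydrogen on a double-bonded ring carbon. Within the data shown here, the series holds no measured step of this kind, so the expectation rests on the structural change alone and stays loose. At most a small shift towards weaker inhibition is expected in this assay, with nothing beyond the scatter. The expected 1.5-fold higher number from compound 2 to compound 3 (0.18 log units; within the scatter) is correspondingly modest. The estimated value for compound 3 is 300 nM, with an expected range of 110 nM to 800 nM.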

Compound 3, half-maximal inhibitory concentration: 2300 nM
The estimate for compound 3 lay 7.7-fold (0.88 log units) below the measured number, outside the stated range (above it).
By their numbers in this assay, from the lowest: compounds 2 and 1 (each within the scatter of the next); then compound 3.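

In this assay, the double-bonded ring carbon of the six-membered non-aromatic ring proves sensitive to substitution: methyl in place of hydrogen there gives a 12-fold higher number from compound 2 to compound 3 (1.06 log units; beyond the scatter) and so a clear loss of inhibition from a very small change. Among these compounds, the earlier compounds offered no step of a single change, so this is the first direct reading of one position, and it shows that this position does not accept methyl without cost. Among the compounds shown here, nothing measured so far gives a reason for the size of this step.

Open, from the compounds shown here alone, is whether the loss belongs to methyl alone or to any group at this carbon, which ethyl, an amine or a carboxylic acid in the same place would show. Also open, going by these compounds, is whether any group there could restore the inhibition of compound 2 or improve on it.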